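A few compounds are considered here, and "the series" means these few. Any claim that something is new, unique, unknown or untested is made for them only; others in the source may bear on it.

Measured so far:
- compound 1 `C#C/C=C\CCCCCCCCCCCCCCC/C=C\CCCC/C=C\CCCCC#C[C@@H](O)C#CCCCCCC/C=C/[C@H](O)C#C`: 11.3 ug/mL
- compound 2 `C#C/C=C\CCCCCCCCCCCCCC/C=C\CCCC/C=C\CCCCC#CC(=O)C#CCCCCCC/C=C/[C@H](O)C#C`: > 30 ug/mL (a limit)
- compound 3 `C#C/C=C\CCCCCCCCCCCCC/C=C/C(=O)CCCC/C=C\CCCCC#C[C@@H](O)C#CCCCCCC/C=C/[C@H](O)C#C`: > 10 ug/mL (a limit)

Among the compounds with values here, in a functional assay on A549 cells (Homo sapiens) for cytotoxicity (a higher number here means that more compound is needed for the effect, a lower number that less compound is needed), compound 1 gives 11.3 ug/mL, the only actual number so far. Compound 2 is reported only as a limit, > 30 ug/mL. Compound 3 is also reported only as a limit, > 10 ug/mL. Compound 1 therefore has no second number in this assay to be ranked against.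

Next in the series is compound 4 `C#C/C=C\CCCCCCCCCCCCCC/C=C\CCCC/C=C\CCCCC#C[C@@H](O)C#CCCCCCC/C=C/[C@H](O)C#C`, not yet measured in this assay. It differs from compound 1 by a group of 4 heavy atoms (4 carbon; no ring) in place of a group of 5 heavy atoms (5 carbon; no ring), on a saturated chain carbon, ten or more bonds along the chain from a double-bonded chain carbon. In words, a group of 4 heavy atoms replaces a group of 5 heavy atoms, on a saturated chain carbon.

Within the data shown here, no two measured compounds differ in one place only, so the series offers no direct precedent for this change. No step beyond the scatter is expected in this assay, in either direction, and the anchor is compound 1 at 11.3 ug/mL. The expected step is a 1.0-fold lower number from compound 1 to compound 4 (0.01 log units; within the scatter). The estimate for compound 4 is 11 ug/mL, with an expected range of 6 ug/mL to 22 ug/mL.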

Compound 4, concentration for half-maximal effect: > 10 ug/mL
Compound 4 gave a limit, no number; the forecaster's own chance of this, stated with the estimate: 20%; the middle value is on the limit's open side.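

In this assay compound 4 is reported only as a limit, > 10 ug/mL. Against compound 1 at 11.3 ug/mL, no step can be read for the group of 4 heavy atoms in place of the group of 5 heavy atoms. The compounds shown leave open whether this replacement changes the read-out in this assay at all, in either direction.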